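Iodo replaced by 3-fluorophenyl: expected step

The compounds below may be only part of what the source reports. "The series", "measured", "known", "first", "only" and "open" are said of these compounds alone.

In a functional assay on MDA-MB-231 cells (Homo sapiens) for antiproliferative activity, read by MTT assay, with a stated time of 72 h (a lower number here means a stronger inhibitor, a higher number a weaker inhibitor), compound 1 (`O=C(CCc1cccc2c1B(O)OC2)Nc1ccc(Br)cc1`) gives 5300 nM and compound 2 (`Cc1ccc(NC(=O)CCc2cccc3c2B(O)OC3)cc1`) gives 1100 nM while compound 3 (`O=C(CCc1cccc2c1B(O)OC2)Nc1cccc(I)c1`) gives 5300 nM as well. Compound 3 therefore stands level with compound 1, and the two share the highest number of the three. Compound 4 (`O=C(CCc1cccc2c1B(O)OC2)Nc1cccc(-c2cccc(F)c2)c1`) carries 3-fluorophenyl in place of iodo on an aromatic carbon, meta to a large group (3-fluorophenyl in place of iodo on an aromatic carbon). Among the compounds with values here, no measured step adds a ring, so the steps bear on this change only indirectly. Changing the group on the amide-type nitrogen gave no change at the digits printed from compound 1 to compound 3 (within the scatter) in one case and a 4.8-fold higher number from compound 2 to compound 3 (0.68 log units; beyond the scatter) in another, and methyl in place of bromo gave a 4.8-fold lower number from compound 1 to compound 2 (0.68 log units; beyond the scatter) as a step of the same size. A modest step is therefore expected in this assay with a weak lean to a lower number, though no step beyond the scatter remains possible. The expected step is a 2.1-fold lower number from compound 3 to compound 4 (0.33 log units; beyond the scatter) as a rough estimate. For compound 4 the estimate is 2500 nM with 700 nM to 8000 nM as the expected range.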

Compound 4, half-maximal inhibitory concentration: 570 nM
Compound 4: the middle estimate sits 4.4-fold (0.64 log units) above what was measured; the measured number lies below the stated range.
By their numbers in this assay, from the lowest: compounds 4 and 2 (each within the scatter of the next); then compounds 1 and 3 (each within the scatter of the next).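

In this assay the swap gives a 9.3-fold lower number from compound 3 to compound 4 (0.97 log units; beyond the scatter), so this aromatic carbon, meta to a large group, accepts 3-fluorophenyl, with 7 heavy atoms and one six-membered aromatic ring, in place of the single iodine atom, and the number falls rather than rises. The earlier compounds shown here showed only exchanges of bromo, iodo and methyl and their placement on the ring, so they gave no reading on adding a ring here. No measurement shown accounts for the size of this step.

The shares of the added ring and of its fluorine remain unseparated, since compound 4 is the only ring-bearing compound shown. Also open, from the compounds shown here alone, is whether a plain phenyl, or a phenyl carrying an amine or a carboxylic acid, would give a similar number at this position.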